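Swapping the Terminal Amine of Compound 2

This account rests on a few compounds, and the source may have more. Where it says the series, first, only, none or still open, it means among the compounds named here.

Of the compounds shown here, two have been measured in a functional assay on A549 cells (Homo sapiens) for cytotoxicity, read by MTT assay, with a stated time of 72 h; a lower number here means a stronger inhibitor, a higher number a weaker inhibitor. Compound 1 `CCN(CC)CCCOc1c(OCc2ccccc2)cc(O)c2c(=O)cc(-c3ccccc3)oc12` gives 3620 nM, and compound 2 `CN(C)CCCCOc1c(OCc2ccccc2)cc(O)c2c(=O)cc(-c3ccccc3)oc12` gives 1090 nM. Compound 2 thus stands at the lower of the two numbers, set apart from compound 1 by the step of a 3.3-fold lower number from compound 1 to compound 2 (0.52 log units; beyond the scatter). Compound 3 `CN1CCN(CCCCOc2c(OCc3ccccc3)cc(O)c3c(=O)cc(-c4ccccc4)oc23)CC1` has not yet been measured. It differs from compound 2 by 4-methylpiperazin-1-yl in place of dimethylamino on a saturated chain carbon, four bonds along the chain from an oxygen on an aromatic ring. Among the compounds with values here, the only measured step, a 3.3-fold lower number from compound 1 to compound 2 (0.52 log units; beyond the scatter), concerns a different exchange of the same amine, so it bears only loosely on the new one; it shows that altering this amine can move the number in this assay by a modest amount, in either direction for all that is known. For compound 3 the expected step is a 1.5-fold higher number from compound 2 to compound 3 (0.17 log units; within the scatter), a small rise that may not stand out from the scatter. The estimated value for compound 3 in this assay is 1600 nM, within a range from 500 nM to 5000 nM.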

Compound 3, half-maximal inhibitory concentration: 2910 nM
For compound 3 the middle estimate is 1.8-fold (0.26 log units) below the measured one; low and high end bracket the measured number.
By their numbers in this assay, from the lowest: compound 2; then compounds 3 and 1 (each within the scatter of the next).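

In this assay, placing 4-methylpiperazin-1-yl where dimethylamino stood, on a saturated chain carbon four bonds along the chain from an oxygen on an aromatic ring, gives a 2.7-fold higher number from compound 2 to compound 3 (0.43 log units; beyond the scatter) and so shows that a ring amine of 7 heavy atoms, in place of an open-chain amine of 3, raises the number from that of compound 2 by more than the scatter. Compound 2 therefore keeps the lowest number of the three, with compound 1 and compound 3 both standing above it by steps beyond the scatter, while the remaining pair shows a 1.2-fold lower number from compound 1 to compound 3 (0.09 log units; within the scatter) and cannot be separated in this assay. No measurement shown here offers an explanation for the size of this step.

The compounds shown leave open whether the higher number goes with the six-membered ring itself or with its second nitrogen, as neither piperidin-1-yl nor morpholin-4-yl on the same chain is among them. They also leave open how a primary amine, or a longer chain ending in dimethylamino, would read at this position.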